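Isopropylcarbonyl in Place of Ethyl on a Fused Ring

The compounds below may be only part of what the source reports. "The series", "measured", "known", "first", "only" and "open" are said of these compounds alone.

Of the compounds shown here, two have been measured in an assay on isolated protein for inhibition of long-chain fatty acid transport protein 1 (Homo sapiens); on this read-out lower numbers stand for stronger inhibition and higher numbers for weaker inhibition. Compound 1, `CCC(=O)c1ccc(N(C)C(=O)CSc2nnc(CNc3ccccc3)n2CC)cc1`, carries a carbonyl-bearing aromatic ring on an amide, and in this assay compound 1 gives 580 nM. Compound 2, `CCc1ccc2oc(CSc3nnc(CNc4ccccc4)n3CC)nc2c1`, shares part of its structure with compound 1 but holds a fused two-ring unit bearing an ethyl group. For compound 2 the assay reports only a limit, > 1000 nM, and not a number. Compound 2 thus stands at the limit of > 1000 nM in this assay, at which 1 of the 2 values shown sits, so its true potency is not known beyond that boundary.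

Compound 3, `CCn1c(CNc2ccccc2)nnc1SCc1nc2cc(C(=O)C(C)C)ccc2o1`, has not been measured. It differs from compound 2 in one place: isopropylcarbonyl in place of ethyl on an aromatic carbon. Going by the values given here, no step between measured compounds is available to guide this change, so any expectation rests on compound 1, which carries a carbonyl group and gives a number, whereas compound 2 does not. The expected step is an at least 1.1-fold lower number from compound 2 to compound 3 (0.04 log units; that floor lies within the scatter), leaning toward stronger inhibition, though its size is uncertain because compound 2 sits at the limit of > 1000 nM in this assay, at which 1 of the 2 values shown sits. Compound 3 is estimated at 900 nM, within a range from 300 nM to 3000 nM.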

Compound 3, half-maximal inhibitory concentration: 600 nM
The estimate for compound 3 lay 1.5-fold (0.18 log units) above the measured number, within the range that was stated.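

In this assay, the aromatic carbon that held ethyl now has a real number attached to it, and the change to isopropylcarbonyl, which brings in a carbonyl and a hydrogen-bond acceptor, is read as an at least 1.6-fold lower number from compound 2 to compound 3 (0.22 log units; that floor lies within the scatter). This shows that the larger group is accepted at this place on the fused ring system, with compound 3 giving 600 nM, and that the change leans toward stronger inhibition, although the smallest step the data allow stays within the usual scatter. The true size of the step could be larger, since the starting point for compound 2 is a limit of the assay and not a number: the limit of > 1000 nM in this assay, at which 1 of the 3 values shown sits.

A single change cannot separate the part played by the carbonyl from that of the branched isopropyl end, and it leaves the true size of the step open. An acetyl group, a carboxylic acid or an amine on the same aromatic carbon would show how much each of these features matters at this place.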